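From phenyl to isopropyl on the core of compound 1

The source may hold more compounds than are shown below. What is called first, only, known or untested is meant among the compounds shown, and "the series" means these compounds.

Values measured so far in a functional assay on SW620/5-FU cells (Homo sapiens) for cytotoxicity, read by MTT assay, with a stated time of 48 h, in the presence of a further agent that is not named here (a lower number here means that less compound is needed, a higher number that more compound is needed for the effect), are these.
Compound 1 `Cn1nc(C(F)(F)F)c2c(-c3ccccc3)cc(NNC(=O)Nc3cc(Cl)nc(Cl)c3)nc21` gives 13100 nM here.
Compound 2 `Cn1ncc2c(-c3ccc(F)cc3)cc(NNC(=O)Nc3cc(Cl)cc(Cl)c3)nc21` gives 54300 nM here.
Compound 3 `Cn1ncc2c(-c3ccccc3)cc(NNC(=O)Nc3cc(Cl)nc(Cl)c3)nc21` gives 76900 nM here.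

Compound 1 holds the lowest number of the three and serves as the starting point. Compound 4 `CC(C)c1cc(NNC(=O)Nc2cc(Cl)nc(Cl)c2)nc2c1c(C(F)(F)F)nn2C` keeps the core of compound 1 but carries isopropyl in place of phenyl on an aromatic carbon, opposite the ring nitrogen, and the count of that change reads isopropyl in place of phenyl on an aromatic carbon in full.

Among the compounds with values here, no measured step touches this phenyl, so there is no direct precedent for the change. Within the data shown here, the only single-place step is a 5.9-fold higher number from compound 1 to compound 3 (0.77 log units; beyond the scatter), and it replaces trifluoromethyl at another place. Among the measured compounds shown here, it shows only that one change on this core can move the number beyond the scatter. Because compound 1 sits at 13100 nM, the lowest of the three numbers, a rise is the more likely direction, though this is a cautious expectation and not a measured trend. A modest upward move, smaller than the trifluoromethyl step, is expected in this assay here. The estimate means a 2.3-fold higher number from compound 1 to compound 4 (0.36 log units; beyond the scatter) as the expected step. Compound 4 is expected at 30000 nM, within an estimated range of 9000 nM to 90000 nM overall.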

Compound 4, half-maximal effective concentration: 19100 nM
For compound 4 the middle estimate is 1.6-fold (0.20 log units) above the measured one; low and high end bracket the measured number.
By their numbers in this assay, from the lowest: compounds 1 and 4 (each within the scatter of the next); then compounds 2 and 3 (each within the scatter of the next).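

In this assay, isopropyl in place of phenyl gives a 1.5-fold higher number from compound 1 to compound 4 (0.16 log units; within the scatter), the first single-place step shown at this carbon, opposite the ring nitrogen. On the core of compound 1, the six-membered aromatic ring of carbon can therefore give way to a branched group with no ring while the number stays within the scatter, whereas the step at the trifluoromethyl place, a 5.9-fold higher number from compound 1 to compound 3 (0.77 log units; beyond the scatter), lies beyond it. No measurement shown here explains why this exchange leaves the number within the scatter.

The compounds shown leave open how far this holds at the same carbon for other groups, such as an amine, a carboxylic acid or a longer chain, since phenyl and isopropyl are the only two groups compared there on this core. Within the data shown here, they also leave open whether isopropyl would behave in the same way on the core of compound 3, where hydrogen stands in place of trifluoromethyl, as the single step at this carbon comes from the trifluoromethyl-bearing core alone.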